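The source may hold more compounds than are shown below. What is called first, only, known or untested is meant among the compounds shown, and "the series" means these compounds.

Compound 2 `NS(=O)(=O)c1ccc(NC(=S)Nc2ccc3ncnc(Nc4ccc(F)c(Br)c4)c3c2)cc1`: > 40000 nM
Compound 1 `COc1ccc(Nc2ncnc3cc(OC)c(OCCCCC(=O)Nc4ccc(S(N)(=O)=O)cc4)cc23)cc1`: > 40000 nM

In a functional assay on A549 cells (Homo sapiens) for antiproliferative activity, read by MTT assay, with a stated time of 72 h (on this read-out higher numbers stand for weaker inhibition and lower numbers for stronger inhibition), compound 2 gives > 40000 nM, which is a limit of the assay and not a number. In this assay compound 1 gives > 40000 nM, likewise a limit rather than a measured number. Both values sit together at the limit of > 40000 nM in this assay, at which 2 of the 2 values shown sit, so no step between measured compounds can be read, and compound 2 stands at the limit with no finer placement among the numbers shown.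

Compound 3 `Cc1ccc(Nc2ncnc3ccc(NC(=S)Nc4ccc(S(N)(=O)=O)cc4)cc23)cc1` is not yet measured. It differs from compound 2 by 4-methylphenyl in place of 3-bromo-4-fluorophenyl on a nitrogen on an aromatic ring. Going by the values given here, with no measured step to lean on and both known values at the limit, the expected step is an at least 1.3-fold lower number from compound 2 to compound 3 (0.12 log units; that floor lies within the scatter), which is as likely to be none beyond the scatter as a modest move in either direction. Compound 3 is estimated at 30000 nM, with a range from 6000 nM to 100000 nM, and a fair chance that only a limit is reported again.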

Compound 3, half-maximal inhibitory concentration: 2840 nM
Compound 3: middle estimate off by 11-fold (1.02 log units), on the high side, and the stated range ends above it.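

In this assay, the change of 4-methylphenyl for 3-bromo-4-fluorophenyl on the nitrogen gives an at least 14-fold lower number from compound 2 to compound 3 (1.14 log units; beyond the scatter), so this position affects the read-out strongly enough to bring the series off the limit. Compound 3 is the only one of the three compounds shown with a measured number, and this is the only single change that can be read. Compound 2 stands at a limit and not a number, so the step gives only a floor and its full size stays unknown: the limit of > 40000 nM in this assay, at which 2 of the 3 values shown sit.

The compounds shown leave open whether the step comes from the 4-methyl group or from the loss of the bromo and fluoro substituents. They also leave open how an unsubstituted phenyl, a 4-chlorophenyl or a 4-ethylphenyl group on the same nitrogen would read.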